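Swapping a pyridine for a furan on a pyridine-based core

A few compounds are considered here, and "the series" means these few. Any claim that something is new, unique, unknown or untested is made for them only; others in the source may bear on it.

Compound 1 `Oc1cccc(-c2cc(-c3ccc(Cl)cc3)nc(-c3ccccn3)c2)c1` gives 30% in an assay on isolated protein for inhibition of DNA topoisomerase 1 (Homo sapiens), with a stated time of 30 min, tested at 100 uM; a lower number here means a weaker effect, a higher number a stronger effect of the compound at the concentration tested.
Compound 2 `Oc1cccc(-c2cc(-c3ccc(Cl)cc3)nc(-c3ccco3)c2)c1` gives 27.1% in this assay.
Compound 3 `Oc1ccc(-c2cc(-c3ccc(Cl)cc3)nc(-c3ccccn3)c2)cc1` gives 12.7% in this assay.

Of the compounds shown here, three have been measured; all share a core that carries a 4-chlorophenyl group, a hydroxyphenyl group and a small heteroaromatic ring. Compound 1 and compound 2 differ only in that small ring: furan-2-yl in place of pyridin-2-yl on an aromatic carbon. This change made a step of a number 2.9 percentage points lower from compound 1 to compound 2 (within the scatter), so the two values cannot be told apart. Compound 1 and compound 3 differ in where the hydroxyl sits on the hydroxyphenyl group: 4-hydroxyphenyl in place of 3-hydroxyphenyl on an aromatic carbon. Here the step was a number 17.3 percentage points lower from compound 1 to compound 3 (beyond the scatter), leaving compound 3 with the lowest of the three numbers.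

Compound 4 `Oc1ccc(-c2cc(-c3ccc(Cl)cc3)nc(-c3ccco3)c2)cc1` has not yet been measured. It stands to compound 3 as compound 2 stands to compound 1: furan-2-yl in place of pyridin-2-yl on an aromatic carbon. This is the same kind of change as before, though the surroundings differ: in compound 1 the place is meta to a 3-hydroxyphenyl group, in compound 3 it is meta to a 4-hydroxyphenyl group. Because the earlier step was a number 2.9 percentage points lower from compound 1 to compound 2 (within the scatter), the change from compound 3 to compound 4 is expected to be small, roughly a number 2.7 percentage points lower from compound 3 to compound 4 (within the scatter). Starting from compound 3 at 12.7%, compound 4 is therefore expected to give about 10%, likely between 0% and 22%. Within the data shown here, with only one earlier example of this change, this estimate rests on thin ground.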

Compound 4, a percentage reported as inhibition, at one concentration (the size of the read-out at that concentration, not a potency): 15.8%
Compound 4: middle estimate off by 5.8 percentage points, on the low side, and the stated range covers the measured number.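

On the core with the 4-hydroxyphenyl group, furan-2-yl in place of pyridin-2-yl gave a step of a number 3.1 percentage points higher from compound 3 to compound 4 (within the scatter) in this assay, so this swap left no readable difference on either core, and the two examples agree: the same change on two cores in this assay, a number 2.9 percentage points lower (within the scatter) from compound 1 to compound 2 and a number 3.1 percentage points higher (within the scatter) from compound 3 to compound 4, 6 percentage points apart, within the scatter of two such steps

The other change also carried over, since 4-hydroxyphenyl in place of 3-hydroxyphenyl gave a step of a number 11.3 percentage points lower from compound 2 to compound 4 (beyond the scatter) with the furan-2-yl group present, and its size agrees with the step seen with the pyridin-2-yl group: the same change on two cores in this assay, a number 17.3 percentage points lower (beyond the scatter) from compound 1 to compound 3 and a number 11.3 percentage points lower (beyond the scatter) from compound 2 to compound 4, 6 percentage points apart, within the scatter of two such steps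

Each change has been seen only twice, however, and each read-out comes from one concentration and is not a potency, so this agreement does not show that either change would behave the same way on a core carrying other groups, nor does it explain why the hydroxyl position matters.

The compounds shown leave open how a thiophene or a pyrimidine would compare with the furan-2-yl and pyridin-2-yl groups. They also leave open what would follow if the hydroxyl gave way to a methoxy group, an amine or a carboxylic acid, or if the chlorine on the 4-chlorophenyl group gave way to fluorine or a methyl group.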